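This account rests on a few compounds, and the source may have more. Where it says the series, first, only, none or still open, it means among the compounds named here.

Measured compounds:
- compound 1, `COc1cc(N(Cc2nc3ccccc3[nH]2)S(=O)(=O)c2ccc(C(C)(C)C)cc2)cc(OC)c1OC`; in a functional assay on MCF7 cells (Homo sapiens) for inhibition, read by MTT assay, with a stated time of 48 h (on this read-out higher numbers stand for weaker inhibition and lower numbers for stronger inhibition), compound 1 gives 33600 nM
- compound 2, `Cc1ccc(S(=O)(=O)N(Cc2nc3ccccc3[nH]2)c2ccc(Cl)cc2)cc1`; in this assay compound 2 gives 38300 nM

Of the compounds shown here, two carry numbers so far, and the two numbers lie within the scatter of each other; nothing separates compound 2 from compound 1 on what has been measured, and neither can be called the stronger or the weaker inhibitor. Both sit in the weak range of this assay.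

The next compound, compound 3 `COc1ccc(N(Cc2nc3ccccc3[nH]2)S(=O)(=O)c2ccc(C)cc2)cc1`, differs from compound 2 in one place: methoxy in place of chloro on an aromatic carbon. Among the measured compounds shown here, no pair of measured compounds shows the effect of this change, so nothing in the present numbers says which way it should move the read-out, if at all. With compound 1 at 33600 nM and compound 2 at 38300 nM the series has so far given one level only, and the expectation for compound 3 is a step that stays within the scatter of that level, without a clear direction.

Compound 3 is therefore expected to give about 35000 nM in this assay, with a range of 15000 nM to 80000 nM. The step from compound 2 that this estimate means is a 1.1-fold lower number from compound 2 to compound 3 (0.04 log units; within the scatter), which is expected to be no change beyond the scatter.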

Compound 3, half-maximal inhibitory concentration: > 50000 nM
Compound 3 gave a limit, no number; the forecaster's own chance of this, stated with the estimate: 15%; middle value at least 1.4-fold (0.15 log units) away from the limit.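

For compound 3 the reading in this assay is a limit and not a number, set by the assay: the limit of > 50000 nM in this assay, at which 1 of the 3 values shown sits. At this aromatic carbon, para to a large group, the change from 4-chlorophenyl to 4-methoxyphenyl gives an at least 1.3-fold higher number from compound 2 to compound 3 (0.11 log units; that floor lies within the scatter), the first read on this position in the series. Methoxy in place of chloro therefore brings no gain in inhibition here, but the floor of the step does not separate the two compounds, so the change may be anything from no shift beyond the scatter to a real loss of unknown size.

From the compounds shown here alone, what an amine, a carboxylic acid or a longer chain such as butoxy would do on this same aromatic carbon remains open, and so does whether any group here can bring the read-out clearly under the level of compound 2. Going by these compounds, it also remains open whether methoxy in place of chloro would read the same way on the core of compound 1, where the sulfonyl side and the other aromatic ring carry different groups.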